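The compounds below may be only part of what the source reports. "The series", "measured", "known", "first", "only" and "open" are said of these compounds alone.

In a functional assay on A-375 cells (Homo sapiens) for cytotoxicity, read by MTT assay, with a stated time of 72 h (a higher number here means a weaker inhibitor, a lower number a stronger inhibitor), three compounds with a shared core have been measured so far. Compound 1 `O=C1c2c[n+]([O-])c3ccccc3c2C(=O)c2c1c1ccccc1n2Cc1cn(CC(O)CO)nn1` gives 440 nM, compound 2 `O=C1c2c[n+]([O-])c3ccccc3c2C(=O)c2c1c1ccccc1n2CCN1CCCC1` gives 430 nM, and compound 3 `CC1(C)O[C@@H](CO)[C@H](Cn2cc(Cn3c4c(c5ccccc53)C(=O)c3c[n+]([O-])c5ccccc5c3C4=O)nn2)O1` gives 190 nM. Compound 2 therefore stands level with compound 1, and compound 3 has a lower number than both.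

The next structure, compound 4 `CCCN1CCN(CCCCn2c3c(c4ccccc42)C(=O)c2c[n+]([O-])c4ccccc4c2C3=O)CC1`, keeps the core of compound 2 and alters only the side chain: 2-(4-propylpiperazin-1-yl)ethyl in place of pyrrolidin-1-yl on a saturated chain carbon, two bonds along the chain from an aromatic nitrogen. In words, 2-(4-propylpiperazin-1-yl)ethyl comes in place of pyrrolidin-1-yl on a saturated chain carbon, two bonds along the chain from an aromatic nitrogen.

Going by the values given here, no measured step makes this exact change, but two measured steps alter the same side chain. The first, a 1.0-fold lower number from compound 1 to compound 2 (0.01 log units; within the scatter), swaps one chain end for a quite different one and leaves the number unmoved. The second, a 2.3-fold lower number from compound 1 to compound 3 (0.36 log units; beyond the scatter), is only modest. Among the compounds with values here, with these two steps as the only guide, a large shift in this assay is not expected, and no step beyond the scatter is predicted, though a slightly lower number seems the likelier direction. The estimated change is a 1.3-fold lower number from compound 2 to compound 4 (0.13 log units; within the scatter). For compound 4 the expected value is 320 nM, with an estimated range of 110 nM to 900 nM.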

Compound 4, half-maximal inhibitory concentration: 870 nM
Estimate against measurement, compound 4: 2.7-fold (0.43 log units) below, and the stated range covers the measured number.
By their numbers in this assay, from the lowest: compound 3; then compounds 2, 1 and 4 (each within the scatter of the next, the first and the last beyond it).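

In this assay, going by these compounds alone, this is the first change to the side chain that moves the number upward beyond the scatter: a 2.0-fold higher number from compound 2 to compound 4 (0.31 log units; beyond the scatter), a modest step, with 2-(4-propylpiperazin-1-yl)ethyl in place of pyrrolidin-1-yl on a saturated chain carbon, two bonds along the chain from an aromatic nitrogen. The position therefore does not tolerate every swap equally, although the effect is small and depends on the reference point, since a 2.0-fold higher number from compound 1 to compound 4 (0.30 log units; within the scatter) stays within the scatter. No measurement available here explains this shift.

The step changes two things at once, the ring at the chain end and the length of the chain that carries it, and the compounds shown cannot separate the two. A 4-propylpiperazin-1-yl ring on the shorter chain of compound 2, or a pyrrolidin-1-yl ring on the longer chain of compound 4, would show which of the two goes with the higher number, and a morpholin-4-yl ring would test a further chain end at this position.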